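Hydrazone series: heteroaryl in place of chlorophenyl

The compounds below may be only part of what the source reports. "The series", "measured", "known", "first", "only" and "open" are said of these compounds alone.

Measured so far:
- compound 1 `Clc1ccc(/C=N/Nc2nc3ccccc3nc2Cc2ccccc2)cc1`: 84000 nM in an assay on isolated protein for inhibition of Amine oxidase [flavin-containing] B (Homo sapiens), read by spectrophotometry; a lower number here means a stronger inhibitor, a higher number a weaker inhibitor
- compound 2 `C/C(=N\Nc1nc2ccccc2nc1Cc1ccccc1)c1ccccn1`: 980000 nM in this assay
- compound 3 `C/C(=N\Nc1nc2ccccc2nc1Cc1ccccc1)c1cccs1`: not yet measured

Within the data shown here, compound 1 has the lower of the two numbers in this assay; the only other number, that of compound 2, stands apart from it by a 12-fold higher number from compound 1 to compound 2 (1.07 log units; beyond the scatter).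

Compound 3 differs from compound 1 by a group of 8 heavy atoms (6 carbon, 1 nitrogen, 1 sulfur; one five-membered aromatic ring with 1 hetero atom) in place of a group of 9 heavy atoms (7 carbon, 1 nitrogen, 1 chlorine; one six-membered aromatic ring of carbon only), on a nitrogen on an aromatic ring. Among the measured compounds shown here, only one measured step touches this position: the one in which the same group leaves and a six-membered aromatic ring with one hetero atom enters, a 12-fold higher number from compound 1 to compound 2 (1.07 log units; beyond the scatter), a large step toward a weaker inhibitor. For the measured compounds named here, no measured pair shows what a five-membered aromatic ring with one hetero atom does at this position, so the size of the step for compound 3 is uncertain. Going by the values given here, on the single step available, the step for compound 3 is expected to be a 3.0-fold higher number from compound 1 to compound 3 (0.47 log units; beyond the scatter), an expected rise beyond the scatter, with a wide range around it. For compound 3 the estimate in this assay is 250000 nM, with a range from 80000 nM to 800000 nM.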

Compound 3, half-maximal inhibitory concentration: 850000 nM
Estimate against measurement, compound 3: 3.4-fold (0.53 log units) below; measured number outside the range, above it.
By their numbers in this assay, from the lowest: compound 1; then compounds 3 and 2 (each within the scatter of the next).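

In this assay, the five-membered ring gives a large step of the same kind as the six-membered one: a 10-fold higher number from compound 1 to compound 3 (1.01 log units; beyond the scatter). At this position, thiophen-2-yl in place of pyridin-2-yl on a carbon with a double bond to nitrogen gives a 1.2-fold lower number from compound 2 to compound 3 (0.06 log units; within the scatter), so the choice between these two heteroaryl rings does not separate compound 2 from compound 3, and compound 1 stands alone at the low end of the three. Nothing measured on these compounds offers a reason for the loss seen with either heteroaryl group.

Compound 2 and compound 3 each differ from compound 1 both in the ring and in the methyl on the carbon with a double bond to nitrogen, so the compounds shown do not tell which of the two changes carries the step; a methyl-bearing hydrazone that keeps the chlorophenyl ring, or a thiophen-2-yl hydrazone without the methyl, would separate them. Also open, from the compounds shown here alone, is what a chlorine, an amine or a carboxylic acid on the thiophen-2-yl ring would do in this assay.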